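The source may report more compounds than this note shows. Statements on the series, on what has been measured and on what is new or still open speak of the compounds shown alone.

Compound 1, `COc1cc(C(=O)O)ccc1OCCCCOc1ccc(C(=O)CC(C)(C)C)c(O)c1C`: 310 nM in an assay on HEK293 cells for positive allosteric modulation of metabotropic glutamate receptor 3 (Rattus norvegicus), read by thallium flux, with a stated time of 2.5 min; on this read-out lower numbers stand for an effect already at smaller amounts and higher numbers for an effect only at larger amounts of compound
Compound 2, `Cc1c(OCCCCOc2ccc(C(=O)CC(C)(C)C)c(O)c2C)cccc1C(=O)O`: 300 nM in this assay
Compound 3, `Cc1c(OCCCCOc2ccccc2C(=O)O)ccc(C(=O)CC(C)C)c1O`: "not determined" (no result reported) in this assay

Compound 1 gives 310 nM in this assay, and compound 2 gives 300 nM; the two values lie within the usual scatter of each other. Compound 3 carries a 2-carboxyphenyl at the end of the chain, and for it the entry in this assay reads "not determined" (no result reported), so no number is known for it and it cannot be placed on the same scale as compound 1 and compound 2.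

Compound 4, `Cc1c(OCCCCOc2cccc(C(=O)O)c2)ccc(C(=O)CC(C)C)c1O`, differs from compound 3 only in one place: 3-carboxyphenyl in place of 2-carboxyphenyl on an oxygen on a saturated carbon. Because no value is known for compound 3, the size of this step cannot be read from a measured pair. Compound 1 and compound 2 show that a carboxyphenyl carried by the same chain, in either of two positions, gives values within the scatter of each other, so no step beyond the scatter is expected in this assay from compound 3 to compound 4. Compound 4 is estimated to give about 500 nM in this assay, within the range 150 nM to 3000 nM.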

Compound 4, half-maximal effective concentration: 1430 nM
Compound 4: the middle estimate sits 2.9-fold (0.46 log units) below what was measured; low and high end bracket the measured number.
By their numbers in this assay, from the lowest: compounds 2 and 1 (each within the scatter of the next); then compound 4.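

Going by these compounds alone, compound 3 has no number in this assay, so no step from it to compound 4 can be read. Going by these compounds, whether 3-carboxyphenyl in place of 2-carboxyphenyl shifts the value in this assay stays open. No measurement shown here offers an explanation for the value of compound 4.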